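The source may report more compounds than this note shows. Statements on the series, on what has been measured and on what is new or still open speak of the compounds shown alone.

Compound 1, `Cc1ccc(-n2cc(-c3cccc(NS(=O)(=O)c4c[nH]c(=O)[nH]c4=O)c3)nn2)cc1`: in a functional assay on HepG2 cells (Homo sapiens) for antiproliferative activity, read by MTT assay, with a stated time of 24 h (a higher number here means a weaker inhibitor, a lower number a stronger inhibitor), compound 1 gives > 20000 nM, which is a limit of the assay rather than a number.
Compound 2, `O=c1[nH]cc(S(=O)(=O)Nc2cccc(-c3cn(-c4ccc(F)cc4)nn3)c2)c(=O)[nH]1`: in this assay compound 2 gives > 20000 nM, again a limit.

Going by the values given here, compound 2 therefore stands at the limit of > 20000 nM in this assay, at which 2 of the 2 values shown sit; its true potency is not pinned down, and the one measured step, a step that the two limits leave unreadable from compound 1 to compound 2, cannot be read in size or direction. Compound 3, `O=c1[nH]cc(S(=O)(=O)Nc2cccc(-c3cn(-c4ccc(Cl)cc4)nn3)c2)c(=O)[nH]1`, differs from compound 2 by chloro in place of fluoro on an aromatic carbon. Among the compounds with values here, no measured step involves this exchange, and the only step available is itself unreadable, so there is nothing to anchor a direction or a size beyond the scatter. The expected step from compound 2 to compound 3 is therefore a step that the limit leaves unreadable from compound 2 to compound 3, with the likeliest outcome another limit. On that basis compound 3 is estimated at 25000 nM, within a range of 8000 nM to 100000 nM.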

Compound 3, half-maximal inhibitory concentration: 1960 nM
Beside the measured number, compound 3's estimate is 13-fold (1.11 log units) above it; the measured number lies below the stated range.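

Going by these compounds alone, at this position, para to a large group, the exchange gives the first step in this assay whose size can be read at all: an at least 10-fold lower number from compound 2 to compound 3 (1.00 log units; beyond the scatter). Measured against the methyl group at the same place, the picture is the same, with an at least 10-fold lower number from compound 1 to compound 3 (1.00 log units; beyond the scatter), so chloro stands apart from both fluoro and methyl on this ring. Compound 3 is the only compound here that gives a number rather than a limit: the limit of > 20000 nM in this assay, at which 2 of the 3 values shown sit.

From the compounds shown here alone, both steps are minimum sizes only, and the real gaps to the two limits stay unknown. Going by these compounds, it also remains open whether the gain belongs to chloro alone or extends to bromo, and what a methoxy group or an amine would do at this same place.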